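The compounds below may be only part of what the source reports. "The series", "measured", "known", "first", "only" and "open" are said of these compounds alone.

Working notes on the series. Compound 1 `Cc1nc(S(C)(=O)=O)ccc1Oc1ncnc(OC2CCN(C(=O)c3noc(C(C)C)n3)CC2)c1F` gives 21.2 nM in a functional assay on isolated protein for inhibition of Glucose-dependent insulinotropic receptor (Homo sapiens), read by HTRF and cAMP accumulation; on this read-out lower numbers stand for an effect already at smaller amounts and higher numbers for an effect only at larger amounts of compound. Going by the values given here, compound 2 `Cc1nc(S(C)(=O)=O)ccc1Oc1ncnc(OC2CCN(C(=O)c3nc(C(C)(C)F)no3)CC2)c1F` gives 43.4 nM in this assay and stands highest of the two numbers recorded; the single measured step, a 2.0-fold higher number from compound 1 to compound 2 (0.31 log units; beyond the scatter), is modest and the only comparison available. Compound 3 `Cc1nc(S(C)(=O)=O)ccc1Oc1ncnc(OC2CCN(C(=O)c3ncc(Cl)cn3)CC2)c1F` is not yet measured. It differs from compound 2 by a group of 7 heavy atoms (4 carbon, 2 nitrogen, 1 chlorine; one six-membered aromatic ring with 2 hetero atoms) in place of a group of 9 heavy atoms (5 carbon, 2 nitrogen, 1 oxygen, 1 fluorine; one five-membered aromatic ring with 3 hetero atoms), on a carbonyl carbon. The step from compound 1 to compound 2 bears on this change only loosely: it also exchanged the group on the carbonyl carbon, and it was modest in size. Among the compounds with values here, no measured compound carries a six-membered ring in that place. The expected outcome is therefore a step of at most similar size, in either direction, which is estimated as a 1.4-fold lower number from compound 2 to compound 3 (0.16 log units; within the scatter), with wide bounds. Compound 3 is expected to give about 30 nM in this assay, with an estimated range from 8 nM to 120 nM.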

Compound 3, half-maximal effective concentration: 6.12 nM
For compound 3 the middle estimate is 4.9-fold (0.69 log units) above the measured one, outside the stated range (below it).
By their numbers in this assay, from the lowest: compound 3; then compound 1; then compound 2.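

At this place on the carbonyl carbon, the first six-membered aromatic ring, 5-chloropyrimidin-2-yl, gives in this assay the largest step yet seen, a 7.1-fold lower number from compound 2 to compound 3 (0.85 log units; beyond the scatter) and beyond what the two five-membered rings showed against each other. The same group also improves on 5-isopropyl-1,2,4-oxadiazol-3-yl, with a 3.5-fold lower number from compound 1 to compound 3 (0.54 log units; beyond the scatter) and so leaves compound 3 with the lowest number of the three, showing that the group on this carbonyl carbon can shift the number in either direction. No supporting data on these compounds offer a reason for this gain.

The compounds shown do not separate the contribution of the chlorine from that of the pyrimidine ring, which pyrimidin-2-yl or 5-methylpyrimidin-2-yl on the same carbonyl carbon would address. As far as these compounds go, how a 5-chloropyridin-2-yl group or a phenyl ring would compare also remains open.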